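Pyrazole carboxamides returning on the tetramethyl core

The source may hold more compounds than are shown below. What is called first, only, known or untested is meant among the compounds shown, and "the series" means these compounds.

Among the compounds with values here, compound 3 `CC1(C)Cc2c(sc(NC(=O)[C@H](O)C(C)(C)C)c2C(N)=O)C(C)(C)O1` stands highest of the three numbers so far in an assay on cells for positive allosteric modulation of Cystic fibrosis transmembrane conductance regulator variant G551D (Homo sapiens), with stated times of 10 min and 2 min, in the presence of a further agent that is not named here (a higher number here means that more compound is needed for the effect, a lower number that less compound is needed), at 7780 nM. Within the data shown here, its nearest neighbour is compound 2 `CC1(C)Cc2c(sc(NC(=O)c3ccn[nH]3)c2C(N)=O)C(C)(C)O1`, at 339 nM, and the furthest is compound 1 `CC1Cc2c(sc(NC(=O)c3ccccc3O)c2C(N)=O)C(C)O1`, at 236 nM; compound 1 shares no single-place step with compound 3 and is noted only for its value. Among the measured compounds shown here, the one step that bears on the change in hand is a 23-fold higher number from compound 2 to compound 3 (1.36 log units; beyond the scatter), which went from a pyrazolyl carbonyl to the hydroxyalkyl carbonyl and was large. For the measured compounds named here, compound 4 `Cc1cn[nH]c1C(=O)Nc1sc2c(c1C(N)=O)CC(C)(C)OC2(C)C` reverses that move on the same core, with 4-methyl-1H-pyrazol-5-yl in place of 1-hydroxy-2,2-dimethylpropyl on a carbonyl carbon; the only addition over compound 2 is the methyl on the pyrazole ring. The expectation for this assay is therefore a large drop of about the same size, a 24-fold lower number from compound 3 to compound 4 (1.39 log units; beyond the scatter), landing close to where compound 2 sits. The estimate for compound 4 is 320 nM, with a range of 110 nM to 950 nM.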

Compound 4, half-maximal effective concentration: 123 nM
For compound 4 the middle estimate is 2.6-fold (0.42 log units) above the measured one, and the stated range covers the measured number.
By their numbers in this assay, from the lowest: compounds 4, 1 and 2 (each within the scatter of the next, the first and the last beyond it); then compound 3.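

In this assay, going back from the hydroxyalkyl carbonyl to a pyrazolyl carbonyl on the same core gives a 63-fold lower number from compound 3 to compound 4 (1.80 log units; beyond the scatter), so the large penalty seen for 1-hydroxy-2,2-dimethylpropyl on this carbonyl carbon appears in both directions of change. The methyl on the aromatic carbon of the pyrazole adds a smaller, separate gain, a 2.8-fold lower number from compound 2 to compound 4 (0.44 log units; beyond the scatter), which is modest but beyond the scatter and shows that this ring carbon accepts a methyl without loss in this assay. Nothing measured here accounts for the size of either step.

As far as these compounds go, it remains open whether ethyl, chlorine or methoxy on that aromatic carbon would extend the methyl step or reverse it. The effect of a methyl on the pyrazole ring nitrogen, and how the hydroxyphenyl carbonyl of compound 1 behaves on the core of compound 4, are also unresolved.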